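Three Benzoate Esters Compared and a Fourth Expected

This account rests on a few compounds, and the source may have more. Where it says the series, first, only, none or still open, it means among the compounds named here.

The study concerns a shared core carrying a benzoate ester whose aromatic substituent is varied. Compound 1 `COC(=O)/C(=C\c1ccc(OC(=O)c2ccccc2)cc1)Sc1ccnc2cc(Cl)ccc12` carries a plain phenyl on the carbonyl carbon, and in a functional assay on Jurkat E6.1 cells (Homo sapiens) for cytotoxicity, read by MTT assay, with a stated time of 24 h (on this read-out lower numbers stand for stronger inhibition and higher numbers for weaker inhibition), compound 1 gives 35700 nM. Compound 2 `COC(=O)/C(=C\c1ccc(OC(=O)c2c(OC)cccc2OC)cc1)Sc1ccnc2cc(Cl)ccc12` gives 37500 nM, and compound 3 `COC(=O)/C(=C\c1ccc(OC(=O)c2cc(OC)c(OC)cc2OC)cc1)Sc1ccnc2cc(Cl)ccc12` gives 9650 nM. On these numbers compound 1 stands second highest of the three: the step of a 1.1-fold higher number from compound 1 to compound 2 (0.02 log units; within the scatter) lies within the scatter, whereas the step of a 3.7-fold lower number from compound 1 to compound 3 (0.57 log units; beyond the scatter) lies beyond it, as does a 3.9-fold lower number from compound 2 to compound 3 (0.59 log units; beyond the scatter).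

Compound 4 `COC(=O)/C(=C\c1ccc(OC(=O)c2cc(OC)c(OC)c(OC)c2)cc1)Sc1ccnc2cc(Cl)ccc12` differs from compound 1 in one place: 3,4,5-trimethoxyphenyl in place of phenyl on a carbonyl carbon. Among the compounds with values here, two measured steps bear on it. Adding two methoxy groups in compound 2 changed nothing, while a trimethoxyphenyl in compound 3 brought a modest lowering. Since compound 4 also carries a trimethoxyphenyl, a modest lowering in this assay is expected, though the differing arrangement leaves the size uncertain. Compound 4 is therefore estimated at 14000 nM, between 5000 nM and 40000 nM, an expected step of a 2.6-fold lower number from compound 1 to compound 4 (0.41 log units; beyond the scatter).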

Compound 4, half-maximal inhibitory concentration: 4570 nM
Compound 4: the middle estimate sits 3.1-fold (0.49 log units) above what was measured; the measured number lies below the stated range.
By their numbers in this assay, from the lowest: compound 4; then compound 3; then compounds 1 and 2 (each within the scatter of the next).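

In this assay, within the data shown here, the group on the carbonyl carbon turns out to matter more than the earlier compounds showed: 3,4,5-trimethoxyphenyl gives the largest steps so far (a 7.8-fold lower number from compound 1 to compound 4 (0.89 log units; beyond the scatter); an 8.2-fold lower number from compound 2 to compound 4 (0.91 log units; beyond the scatter)), and compound 4 has the lowest number of the four. The two trimethoxyphenyl groups also differ from each other (a 2.1-fold lower number from compound 3 to compound 4 (0.32 log units; beyond the scatter)), so the arrangement of the methoxy groups, and not only their number, goes with the read-out at this position, though this step is small. Nothing available explains these differences.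

On these data alone, it remains open whether a phenyl carrying a single methoxy group, a hydroxyl group or an amine would fall in with this order. Also open is whether the order among these compounds would hold in other cell lines or over other exposure times.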